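Side-chain change in a formylhydroxylamine series

The compounds below may be only part of what the source reports. "The series", "measured", "known", "first", "only" and "open" are said of these compounds alone.

compound 1 `CCCCC[C@@H](C(=O)NCNC(=O)c1cc2cccc(OC)c2o1)[C@@H](CC)N(O)C=O`: 126 nM
compound 2 `CCC[C@H](CN(O)C=O)C(=O)NCNC(=O)c1cc2cccc(OC)c2o1`: 1250 nM

Compound 2 holds the higher of the two numbers in an assay on CHO cells for inhibition of bone morphogenetic protein 1 (Homo sapiens), with stated times of 10 min and 60 min; on this read-out lower numbers stand for stronger inhibition and higher numbers for weaker inhibition; compound 1 gives the lower one, and the gap between them lies beyond the scatter. Compound 3 `COc1cccc2cc(C(=O)NCNC(=O)[C@H](Cc3ccccc3)CN(O)C=O)oc12` differs from compound 2 by phenyl in place of ethyl on a saturated chain carbon, two bonds along the chain from a carbonyl carbon. Within the data shown here, no measured pair shows this single change, and compound 1 differs from compound 2 in more than one place, so the expectation rests on little. In this assay the step from compound 2 to compound 3 is estimated at a 2.5-fold lower number from compound 2 to compound 3 (0.40 log units; beyond the scatter), a moderate drop in number. Compound 3 is expected to give 500 nM, with a range of 150 nM to 2000 nM.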

Compound 3, half-maximal inhibitory concentration: 160 nM
Compound 3: middle estimate off by 3.1-fold (0.49 log units), on the high side; the measured number falls inside the stated range.
By their numbers in this assay, from the lowest: compounds 1 and 3 (each within the scatter of the next); then compound 2.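

In this assay, among these compounds, phenyl in place of ethyl on a saturated chain carbon, two bonds along the chain from a carbonyl carbon, gives a 7.8-fold lower number from compound 2 to compound 3 (0.89 log units; beyond the scatter) and is the first single-place step. This position therefore accepts an aromatic ring, and the change moves the number beyond the scatter toward stronger inhibition. Nothing available bears on why the number moves.

Still open, from the compounds shown here alone, is how a cyclohexyl ring, a pyridine ring or an amine would read at this position. Also open, going by these compounds, is whether the step carries over to the side chains of compound 1.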